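The source may report more compounds than this note shows. Statements on the series, on what has been measured and on what is new or still open speak of the compounds shown alone.

Series in a functional assay on MIA PaCa-2 cells (Homo sapiens) for inhibition, read by MTT assay, with a stated time of 3 days; on this read-out higher numbers stand for weaker inhibition and lower numbers for stronger inhibition:
compound 1 `CCN(CC)S(=O)(=O)c1ccc(S(=O)(=O)N2CCC[C@@H](C(=O)NC3CN(C(=O)C4CC4)C3)C2)cc1` gives 3100 nM
compound 2 `CCN(CC)S(=O)(=O)c1ccc(S(=O)(=O)N2CCC[C@@H](C(=O)N(C)C(C)C)C2)cc1` gives 1400 nM
compound 3 `CCN(CC)S(=O)(=O)c1ccc(S(=O)(=O)N2CCC[C@@H](C(=O)NC3CN(C(=O)NC(C)(C)C)C3)C2)cc1` gives 1400 nM

Compound 2 stands level with compound 3 at the digits shown, and the two together hold the lowest number of the three; compound 1 lies furthest from it, a 2.2-fold lower number from compound 1 to compound 2 (0.35 log units; beyond the scatter). The remaining steps give the same picture: a 2.2-fold lower number from compound 1 to compound 3 (0.35 log units; beyond the scatter), while no change at the digits printed from compound 2 to compound 3 (within the scatter). Every measured step alters only the group on the carbonyl carbon of the carboxamide.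

Compound 4 `CCN(CC)S(=O)(=O)c1ccc(S(=O)(=O)N2CCC[C@@H](c3cc(C)no3)C2)cc1` is not yet measured. It differs from compound 2 as follows: 3-methyl-1,2-oxazol-5-yl in place of isopropyl(methyl)carbamoyl on a saturated ring carbon. Here the carboxamide carbonyl itself is exchanged rather than its substituent, so no measured step addresses this change directly. Among the measured compounds shown here, the measured steps, all modest or within the scatter, show only that varied groups at this ring carbon shift the number little. A step of modest size in either direction is therefore plausible, with a slight lean toward a higher number given the loss of the carbonyl that all three measured compounds carry. Compound 4 is expected at 2000 nM, in a range from 600 nM to 7000 nM. The step thus expected is a 1.4-fold higher number from compound 2 to compound 4 (0.15 log units; within the scatter).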

Compound 4, half-maximal inhibitory concentration: 2700 nM
Estimate against measurement, compound 4: 1.4-fold (0.13 log units) below; measured number inside the range.
By their numbers in this assay, from the lowest: compounds 2, 3, 4 and 1 (each within the scatter of the next, the first and the last beyond it).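

In this assay, 3-methyl-1,2-oxazol-5-yl in place of isopropyl(methyl)carbamoyl on the saturated ring carbon gives a 1.9-fold higher number from compound 2 to compound 4 (0.29 log units; within the scatter) and so stays within the scatter. Compounds 1, 2 and 3 all keep the carbonyl and vary only the group it carries, whereas compound 4 shows that this ring carbon can bear a five-membered aromatic ring instead, without a change beyond the scatter from compound 2. No measured information here explains this result.

Still open, from the compounds shown here alone, is whether a carboxylic acid, an amine or the same ring without its methyl would hold this level at the ring carbon. Also open, going by these compounds, is whether any group there can bring the number clearly lower than compound 2 gives.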